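A Pyridinyl Amide in Place of the Methoxyphenyl Amide

A few compounds are considered here, and "the series" means these few. Any claim that something is new, unique, unknown or untested is made for them only; others in the source may bear on it.

Of the compounds shown here, three from one series have been measured in a physicochemical assay for solubility, in phosphate buffer, measured as kinetic solubility, with a stated time of 1 h, at pH 7.4; a lower number here means a less soluble compound, a higher number a more soluble compound. Compound 2 `COc1ccc(NC(=O)COc2cc(C)nc3ccc(OC)cc23)cc1` stands highest of the three, giving 108000 nM in this assay. Its nearest neighbour on the numbers is compound 3 `COc1ccc2nc(C)cc(OCC(=O)Nc3cc(OC)c(OC)c(OC)c3)c2c1`, which in this assay gives 34000 nM, a gap beyond the scatter. Furthest away is compound 1 `COc1ccc2nc(C)cc(NC(=O)C(=O)Nc3cc(C)cc(C)c3)c2c1`, which in this assay gives 10000 nM, again beyond the scatter. Going by the values given here, no two of the measured compounds differ in one place only, so no single step between measured compounds can be read off.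

The next compound, compound 4 `COc1ccc2nc(C)cc(OCC(=O)Nc3c(C)cncc3C)c2c1`, differs from compound 2 in one place:

3,5-dimethylpyridin-4-yl in place of 4-methoxyphenyl on an amide-type nitrogen

Among the compounds with values here, no measured pair shows how such a change plays out in this assay, so the expectation for compound 4 rests on compound 2 alone. The step of a 1.2-fold higher number from compound 2 to compound 4 (0.08 log units; within the scatter) is expected to be small, leaning upward but not clearly beyond the scatter. Compound 4 is therefore estimated to give 130000 nM in this assay, with a range from 45000 nM to 380000 nM.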

Compound 4, solubility: 12000 nM
Beside the measured number, compound 4's estimate is 11-fold (1.03 log units) above it; the whole stated range lies above it.
By their numbers in this assay, from the lowest: compounds 1 and 4 (each within the scatter of the next); then compound 3; then compound 2.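

Going by these compounds alone, this is the first step that can be read at a single place, and it shows that the group on the amide-type nitrogen is not a neutral choice in this assay. Putting 3,5-dimethylpyridin-4-yl in place of 4-methoxyphenyl gives a 9.0-fold lower number from compound 2 to compound 4 (0.95 log units; beyond the scatter) and so takes the series' highest number down to the level of the lowest, even though the two groups match in heavy atoms, hydrogen-bond donors, hydrogen-bond acceptors and net charge. No measurement shown here gives a reason for this drop.

Going by these compounds, the step changes the ring atom and the substituents together, so the share of each stays open. On these data alone, a pyridin-4-yl group without the two methyl groups on the same nitrogen would separate them, and how a morpholine on that ring would read remains unknown.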